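A few compounds are considered here, and "the series" means these few. Any claim that something is new, unique, unknown or untested is made for them only; others in the source may bear on it.

Measured in a functional assay on CWR22R cells (Homo sapiens) for antiproliferative activity, read by propidium iodide staining, with a stated time of 96 h (on this read-out lower numbers stand for stronger inhibition and higher numbers for weaker inhibition), so far:

Compound 1 `CC(O)(CSc1ccc(S(F)(F)(F)(F)F)cc1)C(=O)Nc1cccc(S(F)(F)(F)(F)F)c1` gives 13100 nM.
Compound 2 `CC(O)(CSc1ccc(F)cc1)C(=O)Nc1cccc(S(F)(F)(F)(F)F)c1` gives 30200 nM.
Compound 3 `CC(O)(CS(=O)(=O)c1ccc(S(F)(F)(F)(F)F)cc1)C(=O)Nc1cccc(S(F)(F)(F)(F)F)c1` gives 12300 nM.

Compound 3 and compound 1 lie within the usual scatter of each other, and compound 2 stands apart from both. The change from compound 1 to compound 2 is one fluorine atom in place of a group of 6 heavy atoms (5 fluorine, 1 sulfur; no ring), on an aromatic carbon and it produced a 2.3-fold higher number from compound 1 to compound 2 (0.36 log units; beyond the scatter).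

Compound 4 `CC(O)(CS(=O)(=O)c1ccc(F)cc1)C(=O)Nc1cccc(S(F)(F)(F)(F)F)c1` has not yet been measured. It differs from compound 3 by one fluorine atom in place of a group of 6 heavy atoms (5 fluorine, 1 sulfur; no ring), on an aromatic carbon, the same change as that from compound 1 to compound 2, at the same kind of place. The difference between the core of compound 3 and the core of compound 1 is not broken down here.

Because the same change gave a 2.3-fold higher number from compound 1 to compound 2 (0.36 log units; beyond the scatter), a like-sized step is expected: a 2.3-fold higher number from compound 3 to compound 4 (0.36 log units; beyond the scatter). Compound 4 is therefore expected to give 28000 nM, most likely between 14000 nM and 60000 nM.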

Compound 4, half-maximal inhibitory concentration: 38900 nM
Compound 4: the middle estimate sits 1.4-fold (0.14 log units) below what was measured; measured number inside the range.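

In this assay, putting fluoro in place of the group of 6 heavy atoms (5 fluorine, 1 sulfur) gives a 3.2-fold higher number from compound 3 to compound 4 (0.50 log units; beyond the scatter). The step carries over between the two cores with no difference that can be told apart: the same change on two cores in this assay, a 2.3-fold higher number (0.36 log units; beyond the scatter) from compound 1 to compound 2 and a 3.2-fold higher number (0.50 log units; beyond the scatter) from compound 3 to compound 4, 1.4-fold (0.14 log units) apart, within the scatter of two such steps. This rests on two cores and one place, an aromatic carbon para to a large group, so it neither establishes the step on any further core nor explains its size.

The compounds shown leave open how a trifluoromethyl, a nitrile or an amine on that same aromatic carbon would compare with these two groups. They also leave open whether the step holds on a core with a longer chain.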